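Cinnamamide aminoquinolines: swapping isopropyl for chloro

A few compounds are considered here, and "the series" means these few. Any claim that something is new, unique, unknown or untested is made for them only; others in the source may bear on it.

Compound 1 `CCCc1cc(N)c2cc(NC(=O)/C=C/c3ccc(C(C)C)cc3)ccc2n1`: 520 nM
Compound 2 `Nc1cc(C2CCCCC2)nc2ccc(NC(=O)/C=C/c3ccc(C(F)(F)F)cc3)cc12`: 96 nM
Compound 3 `Cc1cc(N)c2cc(NC(=O)/C=C/c3ccc(C(F)(F)F)cc3)ccc2n1`: 140 nM

In a functional assay on HEK293 cells for activation of melanin-concentrating hormone receptor 1 (Homo sapiens), read by inositol phosphate accumulation (a lower number here means that less compound is needed, a higher number that more compound is needed for the effect), compound 1 gives 520 nM, the highest number of the three measured compounds; compound 3 sits nearer to it and compound 2 further away, and both gaps lie beyond the scatter. Within the data shown here, the only single-place step among the measured compounds is a 1.5-fold higher number from compound 2 to compound 3 (0.16 log units; within the scatter), which concerns the substituent on the shared core and not the cinnamamide aryl ring.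

Compound 4 `CCCc1cc(N)c2cc(NC(=O)/C=C/c3ccc(Cl)cc3)ccc2n1` arises from compound 1 by the change (chloro in place of isopropyl on an aromatic carbon). Among the measured compounds shown here, no measured pair isolates this change. What the numbers show is that compound 3, carrying methyl on the core and trifluoromethyl on the aryl ring, gives 140 nM, while compound 1, with propyl and isopropyl, gives 520 nM; two positions differ at once, so the share of the aryl substituent in that gap cannot be separated. The step of a 1.5-fold higher number from compound 2 to compound 3 (0.16 log units; within the scatter) suggests the core substituent matters little, which would leave the aryl group as the likelier source of that gap. The number for compound 4 in this assay is therefore expected to be 300 nM, within 120 nM to 900 nM, an expected step of a 1.7-fold lower number from compound 1 to compound 4 (0.24 log units; within the scatter).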

Compound 4, half-maximal effective concentration: 96 nM
Estimate against measurement, compound 4: 3.1-fold (0.49 log units) above, outside the stated range (below it).
By their numbers in this assay, from the lowest: compounds 2, 4 and 3 (each within the scatter of the next); then compound 1.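

Among these compounds, with the propyl group on the shared core held fixed, the change from 4-isopropylphenyl to 4-chlorophenyl gives, in this assay, a 5.4-fold lower number from compound 1 to compound 4 (0.73 log units; beyond the scatter), and this is the first reading of this position on its own, where compounds 1 and 3 had differed in two places at once. Among the compounds shown here, the substituent on this aromatic carbon, para to a large group, can therefore move the number beyond the scatter by itself, whereas the only other single-place step, a 1.5-fold higher number from compound 2 to compound 3 (0.16 log units; within the scatter), concerns the core substituent and stays within the scatter. Nothing at hand explains why chloro in place of isopropyl lowers the number.

The compounds shown leave open whether the same change would hold on a core carrying methyl or cyclohexyl in place of propyl, and how chloro and trifluoromethyl compare on one and the same core, as compounds 3 and 4 differ in two places. They also leave open how other groups at this position, such as methoxy, an amine or a carboxylic acid, would read against chloro.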